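Ethyl for methyl on the ester ring of compound 3

A few compounds are considered here, and "the series" means these few. Any claim that something is new, unique, unknown or untested is made for them only; others in the source may bear on it.

Compound 1 `COC(=O)CCNC(=O)[C@@H]1O[P@](=O)(OCOC(=O)c2ccnn2C)OCC1(C)C` – < 0.16 h
Compound 2 `COC(=O)CCNC(=O)[C@@H]1O[P@](=O)(OCOC(=O)c2ocnc2C)OCC1(C)C` – 0.27 h
Compound 3 `COC(=O)CCNC(=O)[C@@H]1O[P@](=O)(OCOC(=O)c2cc(C)nn2C)OCC1(C)C` – < 0.16 h

In an ADME assay on blood (Homo sapiens) for pharmacokinetics (on this read-out lower numbers stand for a shorter-lived compound and higher numbers for a longer-lived compound), compound 3 gives only a limit of the assay, < 0.16 h. Compound 1 likewise sits at a limit, < 0.16 h. For the measured compounds named here, compound 2 is the one member with a number, 0.27 h. Compound 4 `CCc1cc(C(=O)OCO[P@]2(=O)OCC(C)(C)[C@H](C(=O)NCCC(=O)OC)O2)n(C)n1` carries methyl in place of hydrogen on a saturated chain carbon bound to an aromatic carbon, so the change reads methyl to ethyl. Going by the values given here, two measured steps touch the same ring: a step that the two limits leave unreadable from compound 1 to compound 3, and an at least 1.6-fold lower number from compound 2 to compound 3 (0.22 log units; that floor lies within the scatter). The added methyl in that step gave no readable change, and both compounds with this ring sit at the floor described by the limit of < 0.16 h in this assay, at which 2 of the 3 values shown sit. Compound 4 is therefore expected to stay near that floor, with an expected step that the limit leaves unreadable from compound 3 to compound 4, nothing beyond the scatter. The estimate for compound 4 is 0.12 h, between 0.05 h and 0.3 h.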

Compound 4, half-life: < 0.16 h
Compound 4: only a limit was reported; the forecaster's own chance of this, stated with the estimate: 65%; the middle value does not contradict the limit.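

In this assay, for the compounds shown here, compound 4 also gives only a limit, so ethyl in place of methyl on this ring brings no measurable number, and a third ring of this kind sits at the same floor: the limit of < 0.16 h in this assay, at which 3 of the 4 values shown sit. The one step that can be read is an at least 1.6-fold lower number from compound 2 to compound 4 (0.22 log units; that floor lies within the scatter). The steps linking compound 4 to compound 1 and to compound 3 cannot be read, as each joins two limits.

The true size of the methyl to ethyl change stays hidden under the limit. From the compounds shown here alone, whether a longer chain such as propyl, or an amine at this place, would give a readable half-life remains open.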